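Configuration at the ring carbon: from compound 2 to compound 3

The source may hold more compounds than are shown below. What is called first, only, known or untested is meant among the compounds shown, and "the series" means these compounds.

Compound 2 `O=C1C(Cc2n[nH]c3ccccc23)C(=O)N(c2ccccc2)C=CN1CC(=O)N1CCCCc2ccccc21` is the form of the shared core drawn without a configuration at its saturated ring carbon. In a functional assay on CHO cells for agonist activity at Melanocyte-stimulating hormone receptor (Homo sapiens), read by a luciferase reporter, with a stated time of 4 h (a higher number here means that more compound is needed for the effect, a lower number that less compound is needed), compound 2 gives 1.59 nM. Compound 1 `O=C1[C@@H](Cc2n[nH]c3ccccc23)C(=O)N(c2ccccc2)C=CN1CC(=O)N1CCCCc2ccccc21`, drawn R at that carbon, gives 1.59 nM in this assay, and no change at the digits printed from compound 1 to compound 2 (within the scatter). Compound 3 `O=C1[C@H](Cc2n[nH]c3ccccc23)C(=O)N(c2ccccc2)C=CN1CC(=O)N1CCCCc2ccccc21` differs from compound 2 only in that (the two compounds have the same atoms and bonds; at least one stereo element is drawn with a configuration in one of them and without one in the other: 1 of 1 stereo elements differ; a stereocentre at a saturated ring carbon is drawn without a configuration in compound 2 and S in compound 3). For the measured compounds named here, the one measured step that bears on this change is no change at the digits printed from compound 1 to compound 2 (within the scatter), and it left the read-out level; because of the fact that one of compounds 1 and 2 is drawn with a defined configuration and the other without, at the place where they differ, the R form and the undefined form are already indistinguishable in this assay. For compound 3 the S form is therefore expected to sit close to compound 2, with the step of a 1.9-fold higher number from compound 2 to compound 3 (0.28 log units; within the scatter) small and its direction uncertain. Compound 3 is estimated at 3 nM, within the range 1 nM to 30 nM.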

Compound 3, half-maximal effective concentration: 61.7 nM
Estimate against measurement, compound 3: 21-fold (1.31 log units) below, outside the stated range (above it).
By their numbers in this assay, from the lowest: compounds 1 and 2 (each within the scatter of the next); then compound 3.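

The S form at the saturated ring carbon parts clearly from the R form in this assay, with a 39-fold higher number from compound 1 to compound 3 (1.59 log units; beyond the scatter), and that gap can be traced to this one carbon: the fact that compounds 1 and 3 differ only in the configuration as drawn It also parts from the form drawn without a configuration, with a 39-fold higher number from compound 2 to compound 3 (1.59 log units; beyond the scatter), and here too the drawn configuration is the only difference: the fact that one of compounds 2 and 3 is drawn with a defined configuration and the other without, at the place where they differ The earlier pair, level at the digits printed, could not show that this position is sensitive to configuration, whereas the S form shows that it is, with the R form and the undefined form on the lower side.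

The compounds shown leave open whether a gap of this size between the R and S forms would persist on a shared core carrying an amine or a carboxylic acid. They also leave open what the S form would do in any read-out other than this assay.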